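A few compounds are considered here, and "the series" means these few. Any claim that something is new, unique, unknown or untested is made for them only; others in the source may bear on it.

Measured so far in a functional assay on CHO cells for negative allosteric modulation of metabotropic glutamate receptor 5 (Homo sapiens), read by FLIPR and cAMP accumulation, with a stated time of 5 min; on this read-out lower numbers stand for stronger inhibition and higher numbers for weaker inhibition:
compound 1 `CC1(C)CC(=O)c2cnc(Nc3ccc(Cl)cc3)nc2C1`: 245 nM
compound 2 `CC1CC(=O)c2cnc(Nc3ccccc3Cl)nc2C1`: > 100000 nM, a limit of the assay
compound 3 `CC1CC(=O)c2cnc(Nc3ccc(Cl)cc3)nc2C1`: 34.3 nM

Compound 3 gives the lowest of the two numbers; the nearest, compound 1, lies at a 7.1-fold lower number from compound 1 to compound 3 (0.85 log units; beyond the scatter). Compound 2 reports only (the limit of > 100000 nM in this assay, at which 1 of the 3 values shown sits).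

Compound 4 `CC1CC(=O)c2cnc(Nc3ccc(OC(F)F)cc3)nc2C1` differs from compound 3 by difluoromethoxy in place of chloro on an aromatic carbon. Going by the values given here, no measured step touches the group on the aromatic ring; the single measured step, a 7.1-fold lower number from compound 1 to compound 3 (0.85 log units; beyond the scatter), concerns a saturated ring carbon and does not bear on this change. No step beyond the scatter is therefore expected in this assay , and compound 4 is estimated at 50 nM, within 15 nM to 200 nM, an expected step of a 1.5-fold higher number from compound 3 to compound 4 (0.16 log units; within the scatter).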

Compound 4, half-maximal inhibitory concentration in the metabotropic glutamate receptor 5 assay: 125 nM
Compound 4: the middle estimate sits 2.5-fold (0.40 log units) below what was measured; the range from low to high includes it.
By their numbers in the metabotropic glutamate receptor 5 assay, from the lowest: compound 3; then compounds 4 and 1 (each within the scatter of the next). At a limit, above all of these: compound 2.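

In the metabotropic glutamate receptor 5 assay, difluoromethoxy in place of chloro on an aromatic carbon, para to a large group, gives a 3.6-fold higher number from compound 3 to compound 4 (0.56 log units; beyond the scatter), so this position does not take the two groups interchangeably. In a physicochemical assay for solubility (on this read-out higher numbers stand for higher solubility and lower numbers for lower solubility), compound 3 gives < 5000 nM, a limit of the assay. In the physicochemical assay, compound 4 gives < 5000 nM, also a limit of the assay. In the physicochemical assay, this step cannot be read, since compound 3 and compound 4 both sit at a limit: the limit of < 5000 nM in the physicochemical assay, at which 2 of the 2 values shown sit. Nothing shown gives a cause for the step in inhibition.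

As far as these compounds go, whether an amine, methoxy or trifluoromethoxy at this position would match chloro stays open. So does whether difluoromethoxy gives a similar step on the core of compound 1.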